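A few compounds are considered here, and "the series" means these few. Any claim that something is new, unique, unknown or untested is made for them only; others in the source may bear on it.

Measured compounds:
Compound 1 `CCC(C)(C)Cc1c[nH]c(CCc2ccc(-n3cccn3)cc2)n1` gives 106 nM
Compound 2 `CCC(C)(C)Cc1c[nH]c(CCc2ccc(-c3cccc(C#N)n3)cc2)n1` gives 95 nM
Compound 3 `CCC(C)(C)Cc1c[nH]c(CCc2ccc(-c3ccccc3C(=O)O)cc2)n1` gives 101 nM

All three share one core and differ only in the group attached to an aromatic carbon of the benzene ring. They were tested in a functional assay on HEK293 cells for agonist activity at Bombesin receptor subtype-3 (Homo sapiens), read by luminescence and calcium flux, with a stated time of 10 min; on this read-out higher numbers stand for an effect only at larger amounts of compound and lower numbers for an effect already at smaller amounts. Compound 3 holds the second highest of the three numbers, yet none of the three stands apart: the step of a 1.0-fold lower number from compound 1 to compound 3 (0.02 log units; within the scatter) and the step of a 1.1-fold higher number from compound 2 to compound 3 (0.03 log units; within the scatter) are both within the scatter, as is the step of a 1.1-fold lower number from compound 1 to compound 2 (0.05 log units; within the scatter). Three rather different groups at this position thus give numbers that cannot be told apart.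

Compound 4 `CCC(C)(C)Cc1c[nH]c(CCc2ccc(-c3cccc(N)n3)cc2)n1` continues this series with a further exchange at the same place: 6-aminopyridin-2-yl in place of 2-carboxyphenyl on an aromatic carbon. Among the compounds with values here, the steps that bear on it are exactly the three above, and each of them was within the scatter. Without any measured change at this position having moved the number, no step beyond the scatter in this assay is expected in either direction; the expected step is a 1.0-fold lower number from compound 3 to compound 4 (0.00 log units; within the scatter). Compound 4 is therefore estimated to give 100 nM, with a range from 40 nM to 250 nM.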

Compound 4, half-maximal effective concentration: 97 nM
Beside the measured number, compound 4's estimate is 1.0-fold (0.01 log units) above it, within the range that was stated.
By their numbers in this assay, from the lowest: compounds 2, 4, 3 and 1 (each within the scatter of the next).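

Compound 4 supplies the smallest exchange seen so far at this position, with amino in place of cyano on an otherwise unchanged aromatic group, and in this assay this gives a 1.0-fold higher number from compound 2 to compound 4 (0.01 log units; within the scatter). The two larger exchanges agree: a 1.0-fold lower number from compound 3 to compound 4 (0.02 log units; within the scatter) swaps a six-membered aromatic ring of carbon only for one with a hetero atom, and a 1.1-fold lower number from compound 1 to compound 4 (0.04 log units; within the scatter) replaces 1H-pyrazol-1-yl, so a fourth group joins the other three with every step between them inside the scatter. No measurement is available to explain why these four groups cannot be told apart.

As far as these compounds go, all four groups carry an aromatic ring, so it stays open whether a group without one on this aromatic carbon, such as a simple amine, a carboxylic acid or a longer alkyl chain, would give a number in the same range. From the compounds shown here alone, it is equally open whether this insensitivity would persist with a change elsewhere in the shared core, which stays the same in all four compounds.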